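This account rests on a few compounds, and the source may have more. Where it says the series, first, only, none or still open, it means among the compounds named here.

Among the compounds with values here, compound 1 `OCC(CO)OCn1c(Cl)nc2cc(Cl)c(Cl)cc21` is one of three compounds measured in a functional assay on KB cells (Homo sapiens) for inhibition; a higher number here means a weaker inhibitor, a lower number a stronger inhibitor. In this assay compound 1 gives > 100000 nM, which is a limit of the assay and not a number. Compound 2 `CN(C)c1nc2c(Cl)c(Cl)ccc2n1COC(CO)CO` in this assay likewise gives > 100000 nM, again a limit. Compound 3 `OCC(CO)OCn1c(SCc2ccccc2)nc2c(Cl)c(Cl)ccc21` gives 60000 nM in this assay. Within the data shown here, the only step among measured compounds that differ in one place is an at least 1.6-fold lower number from compound 2 to compound 3 (0.22 log units; that floor lies within the scatter), with benzylsulfanyl in place of dimethylamino on an aromatic carbon. So compound 1 stands at the limit of > 100000 nM in this assay, at which 2 of the 3 values shown sit, and no measured value here is a strong inhibitor.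

Compound 4 `OCC(CO)OCn1c(Br)nc2cc(Cl)c(Cl)cc21` is not yet measured. It differs from compound 1 by bromo in place of chloro on an aromatic carbon. Among the measured compounds shown here, none of the measured steps concerns a change from chloro to bromo, so the expectation rests on where compound 1 itself stands, at the limit of > 100000 nM in this assay, at which 2 of the 3 values shown sit. With such a small change at the same place, the step expected from compound 1 to compound 4 in this assay is a number no higher from compound 1 to compound 4 (the limit leaves the size open), which is none beyond the scatter. Compound 4 is therefore estimated to give 100000 nM in this assay, within a range from 40000 nM to 300000 nM, and most likely the assay will again report only a limit.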

Compound 4, half-maximal inhibitory concentration: > 100000 nM
Compound 4: only a limit was reported; the forecaster's own chance of this, stated with the estimate: 70%; the middle value sits exactly at the limit.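

In this assay, within the data shown here, compound 4, like compound 1, gives only a limit and not a number, so no step between these two compounds can be read. The compounds shown leave open how much inhibition compound 1 and compound 4 actually give, and whether bromo in place of chloro on an aromatic carbon changes it at all.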